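This account rests on a few compounds, and the source may have more. Where it says the series, first, only, none or still open, it means among the compounds named here.

Measured in a functional assay on MCF7 cells (Homo sapiens) for cytotoxicity; a lower number here means a stronger inhibitor, a higher number a weaker inhibitor:
- compound 1 `C=C/C=C\[C@H](C)[C@H](OC(N)=O)[C@@H](C)[C@H](O)[C@@H](C)C/C(C)=C\[C@H](C)[C@@H](O)[C@@H](C)/C=C\CCc1ccc(Oc2ccccc2)cc1`: 10000 nM
- compound 2 `C=C/C=C\[C@H](C)[C@H](OC(N)=O)[C@@H](C)[C@H](O)[C@@H](C)C/C(C)=C\[C@H](C)[C@@H](O)[C@@H](C)/C=C\CCc1ccc(C)c(F)c1`: 4000 nM
- compound 3 `C=C/C=C\[C@H](C)[C@H](OC(N)=O)[C@@H](C)[C@H](O)[C@@H](C)C/C(C)=C\[C@H](C)[C@@H](O)[C@@H](C)/C=C\CCc1cccc(O)c1C`: 1000 nM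

Compound 3 has the lowest number of the three in this assay, and its gaps to both other compounds lie beyond the scatter. The next analogue, compound 4 `C=C/C=C\[C@H](C)[C@H](OC(N)=O)[C@@H](C)[C@H](O)[C@@H](C)C/C(C)=C\[C@H](C)[C@@H](O)[C@@H](C)/C=C\CCc1cccc(Cl)c1`, has not yet been measured. It differs from compound 3 as follows: 3-chlorophenyl in place of 3-hydroxy-2-methylphenyl on a saturated chain carbon, two bonds along the chain from a double-bonded chain carbon. In words, 3-chlorophenyl stands in place of 3-hydroxy-2-methylphenyl on a saturated chain carbon, two bonds along the chain from a double-bonded chain carbon.

Within the data shown here, one measured step bears directly on this change: a 4.0-fold lower number from compound 2 to compound 3 (0.60 log units; beyond the scatter). That modest step arrived at the same 3-hydroxy-2-methylphenyl group that compound 4 gives up. Compound 1 also lacks this group and stands at 10000 nM. A modest rise is therefore expected in this assay, no larger than the measured step from compound 2 and possibly within the scatter. The expected change is a 3.0-fold higher number from compound 3 to compound 4 (0.48 log units; beyond the scatter). For compound 4 the estimated value is 3000 nM, with an expected range of 1000 nM to 9000 nM.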

Compound 4, half-maximal inhibitory concentration: 650 nM
Estimate against measurement, compound 4: 4.6-fold (0.66 log units) above; the measured number lies below the stated range.
By their numbers in this assay, from the lowest: compounds 4 and 3 (each within the scatter of the next); then compound 2; then compound 1.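

In this assay, 3-chlorophenyl replaces 3-hydroxy-2-methylphenyl on this saturated chain carbon with a step that stays within the scatter (a 1.5-fold lower number from compound 3 to compound 4 (0.19 log units; within the scatter)). The 3-hydroxy-2-methylphenyl group, with its hydrogen-bond donor and acceptor, is therefore not required to reach the level of compound 3, as a group with neither serves equally well here. The replacement of 3-fluoro-4-methylphenyl by 3-chlorophenyl gives a step beyond the scatter (a 6.2-fold lower number from compound 2 to compound 4 (0.79 log units; beyond the scatter)), so the gain seen with 3-hydroxy-2-methylphenyl is not unique to that group, and no measured evidence accounts for either step.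

The compounds shown do not separate the contributions of the hydroxy and methyl groups within 3-hydroxy-2-methylphenyl. They also leave open how an amine or a carboxylic acid in place of the chlorine, or a longer chain carrying the 3-chlorophenyl ring, would fare.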